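The compounds below may be only part of what the source reports. "The series", "measured", "known", "first", "only" and "open" are said of these compounds alone.

Compound 1 `C[C@H]1[C@H](NCc2sccc2C2CCCC2)C[C@H]2C[C@@H]1C2(C)C` is one of a pair of compounds built on a shared core that carries a side chain with a five-membered aromatic ring with 1 sulfur. In an ADME assay on MDCK cells (Canis lupus familiaris) for cytotoxicity, read by microscopy, with a stated time of 48 h (on this read-out lower numbers stand for higher toxicity in this test and higher numbers for lower toxicity in this test), compound 1 gives 12500 nM. Compound 2 `C[C@H]1[C@H](NCc2sccc2-c2ccccc2)C[C@H]2C[C@@H]1C2(C)C` carries a phenyl in place of the cyclopentyl of compound 1 on an aromatic carbon, and in this assay compound 2 gives 12500 nM. The step of no change at the digits printed from compound 1 to compound 2 (within the scatter) leaves compound 2 level with compound 1 at the digits shown, the two values lying within the scatter of each other.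

Compound 3 `CCOc1ccsc1CN[C@@H]1C[C@H]2C[C@@H]([C@H]1C)C2(C)C` is the next member of the set. Relative to compound 2 the change is ethoxy in place of phenyl on an aromatic carbon. Within the data shown here, only one measured step bears on this change, no change at the digits printed from compound 1 to compound 2 (within the scatter), and it concerned an exchange between two ring groups on an aromatic carbon; no measured step yet follows a move from such a ring group to an ethoxy. That single step was flat, so no shift beyond the scatter is expected here either. Compound 3 is therefore estimated at 12500 nM in this assay, with a range from 5000 nM to 30000 nM, meaning an expected step of no change at the digits printed from compound 2 to compound 3 (within the scatter).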

Compound 3, minimum cytotoxic concentration: 50000 nM
Beside the measured number, compound 3's estimate is 4.0-fold (0.60 log units) below it, and the stated range ends below it.
By their numbers in this assay, from the lowest: compounds 1 and 2 (each within the scatter of the next); then compound 3.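

At this position, on an aromatic carbon of the five-membered aromatic ring with 1 sulfur, the read-out in this assay proves sensitive to the group after all: the exchange of one ring group for another had been flat, but ethoxy gives a 4.0-fold higher number from compound 2 to compound 3 (0.60 log units; beyond the scatter) and a 4.0-fold higher number from compound 1 to compound 3 (0.60 log units; beyond the scatter), a modest shift towards lower toxicity in this test. Since both steps end at compound 3 and are printed as beyond the scatter, ethoxy stands apart from both phenyl and cyclopentyl, not from just one of them. Nothing at hand explains this shift.

The change from phenyl to ethoxy removes the ring, lowers the heavy-atom count and brings in an oxygen with a hydrogen-bond acceptor all at once, so the compounds shown cannot say which of these differences goes with the higher number. Going by these compounds, it remains open whether a plain propyl chain, with no oxygen, would sit with compounds 1 and 2 or with compound 3, and whether a methoxy or a longer butoxy would move the number further.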